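The compounds below may be only part of what the source reports. "The series", "measured", "known", "first", "only" and "open" are said of these compounds alone.

The measured compounds:
Compound 1, `Cn1c(COc2cccc(C(=O)O)c2)nc2ccc(Oc3ccc(F)cc3)nc21`, in a physicochemical assay for lipophilicity, read by LC-MS, in phosphate buffer, measured as octanol-water partition, with a stated time of 30 min, at pH 7.4, tested at 200 mM (a lower number here means a more polar compound, a higher number a more lipophilic compound), gives 1.5.
Compound 2, `Cn1c(COc2cccc(C(=O)O)c2)nc2cnc(Oc3ccc4c(c3)OCC4)cc21`, in this assay gives 0.6.
Compound 3, `Cn1c(COc2cccc(C(=O)O)c2)nc2ccc(Oc3cc(Cl)ccn3)cc21`, in this assay gives 1.2.

Among these three numbers, compound 3 stands second highest. Its nearest neighbour is compound 1, whose number lies somewhat higher, but that gap falls within the usual scatter of repeated measurements, so the two cannot be told apart on this evidence. Compound 2 lies further off, and that gap is beyond the scatter, so compound 2 reads as the more polar of that pair.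

Not yet measured is compound 4, `Cn1c(COc2cccc(C(=O)O)c2)nc2ccc(Oc3ncc(Cl)cc3Cl)cc21`. It differs from compound 3 in a single place: 3,5-dichloropyridin-2-yl in place of 4-chloropyridin-2-yl on an oxygen on an aromatic ring. For the measured compounds named here, no pair of measured compounds here differs in exactly one place, so there is no measured step to lean on; the expectation rests on the change itself, the exchange of 4-chloropyridin-2-yl for 3,5-dichloropyridin-2-yl on the oxygen, with the rest of the molecule kept as it is. Such a change is expected to move the number in this assay upward by a modest amount, a number 0.60 log units higher from compound 3 to compound 4 (beyond the scatter), a step beyond the scatter. Compound 4 is therefore estimated at 1.8, with a range from 1.4 to 2.3.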

Compound 4, distribution coefficient: 1.9
For compound 4 the middle estimate is 0.10 log units below the measured one; the measured number falls inside the stated range.
By their numbers in this assay, from the lowest: compound 2; then compounds 3 and 1 (each within the scatter of the next); then compound 4.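

For the compounds shown here, the earlier compounds held no pair differing in one place only, so this is the first measured step in the set: in this assay the exchange of 4-chloropyridin-2-yl for 3,5-dichloropyridin-2-yl on an oxygen on an aromatic ring gives a number 0.70 log units higher from compound 3 to compound 4 (beyond the scatter) and thus shows that a change at this one place can carry the number past the usual scatter. Going by these compounds alone, the two groups have the same ring type and the same counts of hydrogen-bond donors and acceptors, and neither has a net charge, but the entering group has one more chlorine and its chlorines are placed differently from the single chlorine of the group that leaves. Nothing measured here explains why the number moves.

With only this exchange shown, it remains open whether one of the two chlorines in 3,5-dichloropyridin-2-yl accounts for most of the step or both are needed. Also open, on these data alone, is whether a nitrile or an amine on the same ring would move the number in the same direction, and whether the step would carry over to the core of compound 2.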